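The compounds below may be only part of what the source reports. "The series", "measured", "known", "first", "only" and "open" are said of these compounds alone.

The study examines three ureas and one amide built on a shared core, all tested in a functional assay on SN12C cells (Homo sapiens) for inhibition, read by sulforhodamine B assay, with a stated time of 48 h, tested at 10 uM; a higher number here means a weaker effect of the compound at the concentration tested, a lower number a stronger effect. Compound 1 `COc1cc(Cl)cc(-c2nn(-c3cccc(NC(=O)Nc4cccc(C(F)(F)F)c4)c3)cc2-c2ccncc2)c1` gives 13.9%, compound 2 `COc1cc(Cl)cc(-c2nn(-c3cccc(NC(=O)Nc4ccc(Cl)c(C(F)(F)F)c4)c3)cc2-c2ccncc2)c1` gives 13.8%, and compound 3 `COc1cc(Cl)cc(-c2nn(-c3cccc(NC(=O)c4cc(C(F)(F)F)cc(C(F)(F)F)c4)c3)cc2-c2ccncc2)c1` gives 69.8%. Compound 2 stands lowest of the three numbers, with compound 1 nearest at a step of a number 0.1 percentage points lower from compound 1 to compound 2 (within the scatter), and compound 3 furthest, its value beyond the scatter. The compound not yet measured is compound 4 `COc1cc(Cl)cc(-c2nn(-c3cccc(NC(=O)Nc4ccc(Cl)c(Cl)c4)c3)cc2-c2ccncc2)c1`, which differs from compound 2 by chloro in place of trifluoromethyl on an aromatic carbon.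

Among the measured compounds shown here, only one measured step bears on this change, and only loosely: the step of a number 0.1 percentage points lower from compound 1 to compound 2 (within the scatter), which added a chloro group on the same aromatic ring and moved the number within the scatter. For the measured compounds named here, no measured step exchanges trifluoromethyl for chloro. On this basis compound 4 is expected to stay close to compound 2, with an estimated step of a number 6.2 percentage points higher from compound 2 to compound 4 (within the scatter), and the value for compound 4 in this assay is estimated at 20%, ranging from 8% to 45%.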

Compound 4, a percentage reported as activity, at one concentration (the size of the read-out at that concentration, not a potency): 15.5%
Beside the measured number, compound 4's estimate is 4.5 percentage points above it; measured number inside the range.
By their numbers in this assay, from the lowest: compounds 2, 1 and 4 (each within the scatter of the next); then compound 3.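

In this assay, the exchange of trifluoromethyl for chloro on the aromatic carbon ortho to a chloro group gives a number 1.7 percentage points higher from compound 2 to compound 4 (within the scatter), the only step shown that changes this group directly. Together with a number 1.6 percentage points higher from compound 1 to compound 4 (within the scatter), where 3,4-dichlorophenyl takes the place of 3-(trifluoromethyl)phenyl, it shows that the three ureas cannot be told apart in this assay, although a single chlorine atom replaces a group of 4 heavy atoms at this position. Nothing available explains this tolerance.

The compounds shown leave open whether a methoxy group, a nitrile or a dimethylamino group would be tolerated at this position in the same way. They also leave open whether the number of compound 3, 69.8%, belongs to its amide link or to its different aryl group.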